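The source may hold more compounds than are shown below. What is called first, only, known or untested is meant among the compounds shown, and "the series" means these compounds.

Of the compounds shown here, three of one series have been measured in a functional assay on U-87MG ATCC cells (Homo sapiens) for cytotoxicity, read by MTT assay, with a stated time of 48 h; a higher number here means a weaker inhibitor, a lower number a stronger inhibitor. Compound 1 `C/C(=N/NC(=S)Nc1ccc(Cl)cc1)c1ccccn1` gives 1.7 nM in this assay, compound 2 `CC(=NNC(=S)Nc1cccc(I)c1)c1ccccn1` gives 84 nM, and compound 3 `CC(=NNC(=S)Nc1ccc(I)cc1)c1ccccn1` gives 59 nM. Compound 3 therefore stands with the second highest of the three numbers: its nearest neighbour is compound 2, whose number is within the scatter of its own, so the two cannot be put in order, while compound 1 lies well beyond the scatter with a far lower number.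

The next compound, compound 4 `CC(=NNC(=S)Nc1ccc(Cl)cc1)c1ccccn1`, differs from compound 3 in a single place: chloro in place of iodo on an aromatic carbon. Compound 1, which also bears a chloro group on the same ring and carries the same core, shows the lowest number of the set. Because compound 1 gives 1.7 nM while compound 3 gives 59 nM, the exchange is expected to move compound 4 well below compound 3, by a step of a 15-fold lower number from compound 3 to compound 4 (1.17 log units; beyond the scatter) in this assay, clearly beyond the scatter. Compound 4 is accordingly estimated at 4 nM in this assay, with a likely range from 1 nM to 20 nM.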

Compound 4, half-maximal inhibitory concentration: 1.7 nM
Compound 4: middle estimate off by 2.4-fold (0.37 log units), on the high side, within the range that was stated.
By their numbers in this assay, from the lowest: compounds 1 and 4 (each within the scatter of the next); then compounds 3 and 2 (each within the scatter of the next).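

In this assay, among the compounds shown here, the single exchange of iodo for chloro on an aromatic carbon para to a large group gives a 35-fold lower number from compound 3 to compound 4 (1.54 log units; beyond the scatter), a large step. For the compounds shown here, this is the first comparison between compounds that differ in one place, and it shows that the identity of the halogen at this position matters greatly in this cell assay, even though one heavy atom replaces one heavy atom and the counted hydrogen-bond donors and acceptors stay at zero for both groups. The second step, no change at the digits printed from compound 1 to compound 4 (within the scatter), gives compound 4 and compound 1 values that cannot be told apart, so the double-bond drawing leaves no measurable difference here, and it cannot be said whether the two entries describe different forms, the one difference between them being this: the fact that one of compounds 1 and 4 is drawn with a defined configuration and the other without, at the place where they differ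

As far as these compounds go, what remains open is how a fluoro or bromo group, a methyl group, a methoxy group or an amine would stand on this same carbon relative to chloro and iodo. Also open, from the compounds shown here alone, is whether chloro keeps its advantage over iodo when the halogen sits elsewhere on the ring, or when the shared core is changed.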